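Swapping ethyl for acetyl on the piperazine ring

A few compounds are considered here, and "the series" means these few. Any claim that something is new, unique, unknown or untested is made for them only; others in the source may bear on it.

- compound 1 `COc1ccc(CN(C(=O)CSC(=S)N2CCOCC2)c2cc(OC)c(OC)c(OC)c2)cc1`: 7220 nM
- compound 2 `CCN1CCN(CC(=O)N(Cc2ccc(OC)cc2)c2cc(OC)c(OC)c(OC)c2)CC1`: 16100 nM

Both numbers come from a functional assay on KYSE-450 cells (Homo sapiens) for inhibition, read by CCK-8 assay, with a stated time of 48 h; a lower number here means a stronger inhibitor, a higher number a weaker inhibitor. Compound 2 has the higher of the two numbers, which makes it the weaker inhibitor of this pair.

The next molecule, compound 3 `COc1ccc(CN(C(=O)CN2CCN(C(C)=O)CC2)c2cc(OC)c(OC)c(OC)c2)cc1`, keeps everything in compound 2 except for one group. It has acetyl in place of ethyl on an amine nitrogen in a ring.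

Among the compounds with values here, no measured step makes this exact swap. The closest evidence is a 2.2-fold higher number from compound 1 to compound 2 (0.35 log units; beyond the scatter). That modest step replaced the whole ring-bearing group on the saturated chain carbon bound to a carbonyl carbon, whereas the new change alters only the group on the ring nitrogen. The data do not show which way acetyl should move the number, so little change is expected, probably none beyond the scatter. The expected change is a 1.2-fold lower number from compound 2 to compound 3 (0.09 log units; within the scatter). In this assay, compound 3 is estimated at 13000 nM, with an expected range of 5000 nM to 35000 nM.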

Compound 3, half-maximal inhibitory concentration: 10800 nM
Compound 3: middle estimate off by 1.2-fold (0.08 log units), on the high side; measured number inside the range.
By their numbers in this assay, from the lowest: compounds 1, 3 and 2 (each within the scatter of the next, the first and the last beyond it).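

Within the data shown here, on the amine nitrogen in the ring, the first direct reading of acetyl in place of ethyl is a 1.5-fold lower number from compound 2 to compound 3 (0.17 log units; within the scatter), so in this assay this position tolerates the swap without a change that can be told from the scatter. The second step, a 1.5-fold higher number from compound 1 to compound 3 (0.17 log units; within the scatter), places compound 3 within the scatter of compound 1 as well, even though a 2.2-fold higher number from compound 1 to compound 2 (0.35 log units; beyond the scatter) lies beyond it, so compound 3 cannot be ranked firmly against either neighbour. Nothing measured on these compounds explains the small step or says what acetyl does here.

With only ethyl and acetyl shown on this ring nitrogen, it remains open whether a plain hydrogen, a longer chain such as butyl, or a larger acyl group such as benzoyl would move the number beyond the scatter. As far as these compounds go, it is also open whether a group on this nitrogen could give a number clearly lower than those of compound 1 and compound 3, or whether the rest of the shared core sets the level seen here.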